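Moving a trifluoromethyl group on the acyl-side phenyl ring

The compounds below may be only part of what the source reports. "The series", "measured", "known", "first", "only" and "open" are said of these compounds alone.

Measured compounds:
compound 1, `CN(C(=O)NC(=O)c1cccc(C(F)(F)F)c1)c1nc(C(F)(F)F)c(C(=O)N/N=C/c2ccc(C(F)(F)F)cc2)s1`, 7.71 ug/mL
compound 2, `CN(C(=O)NC(=O)c1cccc(C(F)(F)F)c1)c1nc(C(F)(F)F)c(C(=O)N/N=C/c2ccccc2C(F)(F)F)s1`, 10.4 ug/mL
compound 3, `CN(C(=O)NC(=O)c1ccc(C(F)(F)F)cc1)c1nc(C(F)(F)F)c(C(=O)N/N=C/c2cccc(C(F)(F)F)c2)s1`, 7.95 ug/mL

All three compounds share one core and were tested in a functional assay on HepG2 cells (Homo sapiens) for inhibition, read by MTT assay, with a stated time of 72 h; on this read-out higher numbers stand for weaker inhibition and lower numbers for stronger inhibition. Compound 3 gives 7.95 ug/mL, the second highest of the three numbers; its gap to compound 1 and its gap to compound 2 both lie within the scatter, so no order among these three can be claimed.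

Compound 4, `CN(C(=O)NC(=O)c1cccc(C(F)(F)F)c1)c1nc(C(F)(F)F)c(C(=O)N/N=C/c2cccc(C(F)(F)F)c2)s1`, is not yet measured. Its difference from compound 3 is 3-(trifluoromethyl)phenyl in place of 4-(trifluoromethyl)phenyl on a carbonyl carbon. Going by the values given here, the only measured step here also moves a trifluoromethyl group around a phenyl ring, but on the other side of the core: a 1.3-fold higher number from compound 1 to compound 2 (0.13 log units; within the scatter). That step stayed within the scatter. Among the compounds with values here, no step touches the carbonyl-side ring directly, so the expectation rests on this one analogy, and it points to no change beyond the scatter. The step from compound 3 to compound 4 is therefore estimated as a 1.0-fold higher number from compound 3 to compound 4 (0.00 log units; within the scatter). Compound 4 is expected to give about 8 ug/mL, within a range from 4 ug/mL to 16 ug/mL.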

Compound 4, half-maximal inhibitory concentration: 5.79 ug/mL
Beside the measured number, compound 4's estimate is 1.4-fold (0.14 log units) above it; measured number inside the range.
By their numbers in this assay, from the lowest: compounds 4, 1, 3 and 2 (each within the scatter of the next).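

In this assay the move from 4-(trifluoromethyl)phenyl to 3-(trifluoromethyl)phenyl on the carbonyl carbon can now be read directly, and a 1.4-fold lower number from compound 3 to compound 4 (0.14 log units; within the scatter) stays inside the usual scatter, so this change has no readable effect on the number. On the carbon with a double bond to nitrogen, the same result adds two comparisons, a 1.8-fold lower number from compound 2 to compound 4 (0.25 log units; within the scatter) and a 1.3-fold lower number from compound 1 to compound 4 (0.12 log units; within the scatter), and both also stay within the scatter, so all three placements of trifluoromethyl on that ring remain indistinguishable here. No measurement shown here offers an explanation for these small differences. Going by these compounds, what remains open is how 2-(trifluoromethyl)phenyl would behave on the carbonyl carbon. Also open, on these data alone, is whether an amine or a carboxylic acid in place of trifluoromethyl on that ring would shift the number beyond the scatter.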